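Chloro for Nitro on a Low-Nanomolar Aryl Compound

This account rests on a few compounds, and the source may have more. Where it says the series, first, only, none or still open, it means among the compounds named here.

Compound 1 (`O=C1NNC(=O)C2(CSC3=C2C(=O)c2ncccc2C3=O)N1`) carries the shared core alone, and in a functional assay on MT4 cells (Homo sapiens) for antiproliferative activity, read by MTT assay, with a stated time of 96 h (a higher number here means a weaker inhibitor, a lower number a stronger inhibitor), compound 1 gives 550 nM; 500 nM; 550 nM (3 entries) across repeated readings. Compound 2 (`O=C1NN(c2ccc([N+](=O)[O-])cc2)C(=O)C2(CSC3=C2C(=O)c2ncccc2C3=O)N1`) adds a 4-nitrophenyl group. In this assay, going by the values given here, compound 2 gives 5 nM as its only single number there, a further entry offering none, and that reading lies well below those of compound 1.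

Compound 3 (`O=C1NN(c2ccc(Cl)cc2)C(=O)C2(CSC3=C2C(=O)c2ncccc2C3=O)N1`) is still unmeasured and differs from compound 2 by chloro in place of nitro on an aromatic carbon. Among the compounds with values here, no measured step shows this exchange. Compound 3 keeps the phenyl ring, so it is expected to stay close to compound 2 (5 nM) rather than fall back toward compound 1. A modest weakening is expected (a 2.4-fold higher number from compound 2 to compound 3 (0.38 log units; beyond the scatter)), little beyond the scatter. For compound 3 the estimate is 12 nM within an expected range of 3 nM to 60 nM in this assay.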

Compound 3, half-maximal inhibitory concentration: 150 nM
Compound 3: middle estimate off by 13-fold (1.10 log units), on the low side; the whole stated range lies below it.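

Exchanging 4-nitrophenyl for 4-chlorophenyl in this assay gives a 30-fold higher number from compound 2 to compound 3 (1.48 log units; beyond the scatter), so keeping the phenyl ring is not enough to keep the low reading, and the group on that ring matters greatly at this position. Even so, compound 3 gives 150 nM and compound 1 gives 550 nM; 500 nM; 550 nM (3 entries), so the printed values leave the chloro-bearing aryl compound between the other two. Repeat readings are shown for only one compound in this assay, and they lie close together: the several entries of compound 1 in this assay, 550 nM; 500 nM; 550 nM (3 entries)

These compounds cannot separate the loss of nitro from the arrival of chloro, and they give no cause for the step. From the compounds shown here alone, how a plain phenyl ring, or an amine, nitrile or methoxy group at the same place, would read remains open.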